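1-Hydroxyethyl in Place of Methoxymethyl: Expected Half-Life

A few compounds are considered here, and "the series" means these few. Any claim that something is new, unique, unknown or untested is made for them only; others in the source may bear on it.

Three measured compounds share one core and differ only in what sits on an oxygen on an aromatic ring. Compound 1 `COCCOc1ccc2c(Oc3ccc(Nc4nccc5[nH]cc(-c6ccc(F)cc6)c(=O)c45)cc3F)ccnc2c1` carries a 2-methoxyethyl chain there; in an ADME assay on microsomes from liver (Rattus norvegicus) for metabolic stability (on this read-out lower numbers stand for a shorter-lived compound and higher numbers for a longer-lived compound), compound 1 gives 1.73 h. Compound 2 `CC(C)COc1ccc2c(Oc3ccc(Nc4nccc5[nH]cc(-c6ccc(F)cc6)c(=O)c45)cc3F)ccnc2c1` carries an isobutyl chain and gives 1.5 h, while compound 3 `O=c1c(-c2ccc(F)cc2)c[nH]c2ccnc(Nc3ccc(Oc4ccnc5cc(O)ccc45)c(F)c3)c12` has only hydrogen on that oxygen and gives 0.893 h. Compound 1 thus holds the highest of the three numbers, yet all three lie within the scatter of one another: a 1.9-fold lower number from compound 1 to compound 3 (0.29 log units; within the scatter) and a 1.7-fold lower number from compound 2 to compound 3 (0.23 log units; within the scatter).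

Compound 4 `CC(O)COc1ccc2c(Oc3ccc(Nc4nccc5[nH]cc(-c6ccc(F)cc6)c(=O)c45)cc3F)ccnc2c1` has not yet been measured. It differs from compound 1 by 1-hydroxyethyl in place of methoxymethyl on a saturated chain carbon bound to an oxygen on an aromatic ring. Within the data shown here, the step that bears most directly on this change is the one in which another group replaced methoxymethyl at the same place: a 1.2-fold lower number from compound 1 to compound 2 (0.06 log units; within the scatter). Even removing the whole chain, from compound 1 to compound 3, stayed within the scatter. Among the measured compounds shown here, nothing among the measured steps therefore points to a step beyond the scatter in this assay, in either direction, for compound 4. Compound 4 is accordingly estimated at 1.4 h, with a range from 0.8 h to 2.6 h. That estimate means an expected 1.2-fold lower number from compound 1 to compound 4 (0.09 log units; within the scatter).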

Compound 4, half-life: 1.42 h
For compound 4 the middle estimate is 1.0-fold (0.01 log units) below the measured one; the measured number falls inside the stated range.
By their numbers in this assay, from the lowest: compounds 3, 4, 2 and 1 (each within the scatter of the next).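

With 1-hydroxyethyl in place of methoxymethyl, the chain keeps the same atoms but now has a hydrogen-bond donor, which neither the chain of compound 1 nor that of compound 2 has, and in this assay this change gives (a 1.2-fold lower number from compound 1 to compound 4 (0.09 log units; within the scatter)). Compared with the isobutyl chain, hydroxy in place of methyl gives (a 1.1-fold lower number from compound 2 to compound 4 (0.02 log units; within the scatter)), and compared with hydrogen on the oxygen, the 2-hydroxypropyl chain gives (a 1.6-fold higher number from compound 3 to compound 4 (0.20 log units; within the scatter)), so the new compound stays within the scatter of all three others. At this position, then, a chain with a hydroxy group, a chain with an ether oxygen, an all-carbon chain and plain hydrogen cannot be told apart by this read-out, and no supporting measurement is available to explain why the numbers stay so close.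

An amine or a carboxylic acid on this chain, or a longer chain, is not among the compounds shown, so it remains open whether any group at this position can move the half-life beyond the scatter. As far as these compounds go, whether these compounds would also stay this close in any other test remains open too.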